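The compounds below may be only part of what the source reports. "The series", "measured", "known", "first", "only" and "open" are said of these compounds alone.

Of the compounds shown here, three built on one shared core have been measured in a physicochemical assay for lipophilicity, at pH 7.4; a higher number here means a more lipophilic compound, a lower number a more polar compound. Compound 1 `CNC(=O)c1cc(C(=O)NC2CC2)cn(Cc2cccc(OC)c2)c1=O` gives 3, compound 2 `CNC(=O)c1cc(C(=O)NC2CC2)cn(Cc2ccc3nc[nH]c3c2)c1=O` gives 1.2, and compound 3 `CNC(=O)c1cc(C(=O)NC2CC2)cn(CC2CCOCC2)c1=O` gives 1.5. Compound 3 thus holds the second highest of the three numbers: its nearest neighbour is compound 2, with the gap a number 0.30 log units higher from compound 2 to compound 3 (within the scatter) inside the scatter, while the gap to compound 1, a number 1.50 log units lower from compound 1 to compound 3 (beyond the scatter), is large and beyond it.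

Compound 4 `CNC(=O)c1cc(C(=O)NC2CC2)cn(Cc2cccc([C@@H](C)O)c2)c1=O` has not yet been measured. It differs from compound 3 in one place: 3-(1-hydroxyethyl)phenyl in place of oxan-4-yl on a saturated chain carbon bound to an aromatic nitrogen. Among the compounds with values here, two measured steps bear on this exchange. The step of a number 1.50 log units lower from compound 1 to compound 3 (beyond the scatter) describes the removal of an aromatic ring carrying a methoxy group in favour of oxan-4-yl; compound 4 runs that exchange backwards, restoring an aromatic ring of carbon only, though one that now carries a hydrogen-bond donor. The step of a number 0.30 log units higher from compound 2 to compound 3 (within the scatter), where the aromatic ring that left carried a donor of its own, stayed within the scatter. The account therefore expects a rise in this assay that does not reach the number compound 1 shows, an estimated step of a number 0.80 log units higher from compound 3 to compound 4 (beyond the scatter). Compound 4 is estimated at 2.3, expected to fall between 1.8 and 2.8.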

Compound 4, distribution coefficient: 2.2
Compound 4: the middle estimate sits 0.10 log units above what was measured, within the range that was stated.
By their numbers in this assay, from the lowest: compounds 2 and 3 (each within the scatter of the next); then compound 4; then compound 1.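

In this assay, the new compound gives the first clear separation among the groups carrying a hydrogen-bond donor at this place on a saturated chain carbon bound to an aromatic nitrogen: 3-(1-hydroxyethyl)phenyl stands apart from oxan-4-yl, with a number 0.70 log units higher from compound 3 to compound 4 (beyond the scatter), and from 1H-benzimidazol-6-yl, with a number 1.00 log units higher from compound 2 to compound 4 (beyond the scatter). An aromatic group with a donor therefore does not by itself bring a compound to the level of compound 2, whose number lay within the scatter of that of compound 3. Within the data shown here, the aromatic ring of carbon only also allows the first comparison in which only the group on an aromatic carbon changes, and 1-hydroxyethyl in place of methoxy gives a number 0.80 log units lower from compound 1 to compound 4 (beyond the scatter), so this single exchange on the ring moves the number beyond the scatter.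

The compounds shown leave open how a hydroxymethyl group, a primary amine or a carboxylic acid in place of 1-hydroxyethyl would read here, and whether the opposite configuration at the stereocentre would match compound 4. Nothing available explains the size of these steps.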